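The source may hold more compounds than are shown below. What is called first, only, known or untested is meant among the compounds shown, and "the series" means these compounds.

Compounds and values in an assay on brain with Translocator protein (Rattus norvegicus) as the target; on this read-out lower numbers stand for stronger inhibition and higher numbers for weaker inhibition:

compound 1 `CCN(Cc1ccccc1)Cc1nc2ccccc2c(-c2ccccc2)c1C(=O)N(CC)CC` — 373 nM
compound 2 `CCN(Cc1ccccc1)Cc1nc2ccccc2c(-c2ccccc2)c1C(=O)NCc1ccccc1` — 2900 nM
compound 3 `CCCN(CCC)C(=O)c1c(CN(CC)Cc2ccccc2)nc2ccccc2c1-c1ccccc1` — not yet measured

Among the compounds with values here, compound 2 stands at the highest of the two numbers so far in this assay; its nearest neighbour is compound 1, which gives 373 nM, a gap that lies beyond the scatter. Within the data shown here, the only measured step with a bearing on the new compound is the one that connects these two: a 7.8-fold higher number from compound 1 to compound 2 (0.89 log units; beyond the scatter), a change on the carbonyl carbon whose other neighbour is aromatic carbon.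

Compound 3 carries the change (dipropylamino in place of benzylamino on a carbonyl carbon). This undoes the introduction of the benzyl group and restores a dialkyl amide closely resembling the diethylamide of compound 1, with propyl chains in place of ethyl. One step on this position is known, and it was modest in size; the return to a dialkylamino group is therefore expected to bring the number back down, with a 5.8-fold lower number from compound 2 to compound 3 (0.76 log units; beyond the scatter) as the expected size of the move. Compound 3 is accordingly estimated at 500 nM, within a range from 150 nM to 1600 nM.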

Compound 3, half-maximal inhibitory concentration: 456 nM
For compound 3 the middle estimate is 1.1-fold (0.04 log units) above the measured one; low and high end bracket the measured number.
By their numbers in this assay, from the lowest: compounds 1 and 3 (each within the scatter of the next); then compound 2.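

In this assay, replacing benzylamino with dipropylamino on the carbonyl carbon gives a 6.4-fold lower number from compound 2 to compound 3 (0.80 log units; beyond the scatter), so the higher number of compound 2 does not carry over to this dialkylamino group. Against the diethylamino group, the same position gives a 1.2-fold higher number from compound 1 to compound 3 (0.09 log units; within the scatter), which places compound 1 and compound 3 level and shows that, among these three compounds, the amide with benzylamino is the one that stands apart. No measurement is at hand that would account for this difference.

The step from benzylamino to dipropylamino removes the six-membered aromatic ring and the amide hydrogen together, so the compounds shown do not tell which of the two goes with the higher number of compound 2. A propylamino group, which keeps the amide hydrogen without the ring, and a dibenzylamino group, which keeps the ring without the amide hydrogen, would separate the two, while a dibutylamino group or a piperidine amide would show how far the dialkyl side of this position extends.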